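Bromo to Methoxy on the Pendant Aryl Ring

The compounds below may be only part of what the source reports. "The series", "measured", "known", "first", "only" and "open" are said of these compounds alone.

Compound 3 `CNC(=O)c1cc(Oc2ccc(NC(=O)c3cc(-c4ccc(Br)cc4)ncn3)cc2)ccn1` gives in a functional assay on PC-3 cells (Homo sapiens) for cytotoxicity, read by MTT assay, with a stated time of 72 h (on this read-out higher numbers stand for weaker inhibition and lower numbers for stronger inhibition), only > 100000 nM, a limit of the assay and not a number. Compound 1 `CNC(=O)c1cc(Oc2ccc(NC(=O)c3cc(-c4ccc(Cl)cc4)ncn3)cc2)ccn1` likewise reaches only the limit > 100000 nM in this assay. Compound 2 `CCc1ccc(-c2cc(C(=O)Nc3ccc(Oc4ccnc(C(=O)NC)c4)cc3)ncn2)cc1` gives 29300 nM in this assay. Among these, an at least 3.4-fold lower number from compound 1 to compound 2 (0.53 log units; beyond the scatter) and an at least 3.4-fold higher number from compound 2 to compound 3 (0.53 log units; beyond the scatter), while a step that the two limits leave unreadable from compound 1 to compound 3. Compound 4 `CNC(=O)c1cc(Oc2ccc(NC(=O)c3cc(-c4ccc(OC)cc4)ncn3)cc2)ccn1` differs from compound 3 by methoxy in place of bromo on an aromatic carbon. No measured step touches methoxy; the only steps that bear on the bromo position are an at least 3.4-fold higher number from compound 2 to compound 3 (0.53 log units; beyond the scatter) and a step that the two limits leave unreadable from compound 1 to compound 3, and most of the shown values sit at the limit of > 100000 nM in this assay, at which 2 of the 3 values shown sit. Compound 4 is therefore expected to give about 60000 nM in this assay, between 15000 nM and 100000 nM, meaning an expected step of an at least 1.6-fold lower number from compound 3 to compound 4 (0.22 log units; that floor lies within the scatter), with a real chance that only a limit is reported again.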

Compound 4, half-maximal inhibitory concentration: 38800 nM
Beside the measured number, compound 4's estimate is 1.5-fold (0.19 log units) above it; low and high end bracket the measured number.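

In this assay, methoxy in place of either halogen gives a readable number: an at least 2.5-fold lower number from compound 3 to compound 4 (0.41 log units; beyond the scatter), and an at least 2.5-fold lower number from compound 1 to compound 4 (0.41 log units; beyond the scatter). Set against ethyl, methoxy gives a 1.3-fold higher number from compound 2 to compound 4 (0.12 log units; within the scatter), so these two groups cannot be told apart at this position, although one carries an oxygen and the other does not. Compound 1 and compound 3 remain at a limit of the assay, not a number: the limit of > 100000 nM in this assay, at which 2 of the 4 values shown sit.

On these data alone, whether an amine, a carboxylic acid or a longer chain at this position would give a lower number than compound 2 and compound 4 stays open.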